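Moving a Methoxy Group on the Ketone-Bearing Ring

The compounds below may be only part of what the source reports. "The series", "measured", "known", "first", "only" and "open" are said of these compounds alone.

Compound 1 `COc1ccc(/C=C/c2cc(OC)cc(OC)c2/C=C/C(=O)c2ccc(N)cc2)cc1` is one of three related compounds tested in a functional assay on A549 cells (Homo sapiens) for antiproliferative activity, read by MTT assay, with a stated time of 48 h; a higher number here means a weaker inhibitor, a lower number a stronger inhibitor. Compound 1 gives 3.8 ug/mL, the lowest of the three numbers. Compound 2 `COc1ccc(/C=C/c2cc(OC)cc(OC)c2/C=C/C(=O)c2ccc(OC)cc2)cc1` gives 4.5 ug/mL, and compound 3 `CCCCCCCCCCCCOc1ccc(C(=O)/C=C/c2c(/C=C/c3ccc(OC)cc3)cc(OC)cc2OC)cc1` gives 7.9 ug/mL. The step of a 1.2-fold higher number from compound 1 to compound 2 (0.07 log units; within the scatter) shows that exchanging the amino group for a methoxy group hardly shifts the number, and a 1.8-fold higher number from compound 2 to compound 3 (0.24 log units; within the scatter) is also small. Compound 4 `COc1ccc(/C=C/c2cc(OC)cc(OC)c2/C=C/C(=O)c2cccc(OC)c2)cc1` differs from compound 1 by 3-methoxyphenyl in place of 4-aminophenyl on a carbonyl carbon. The step from compound 1 to compound 2 bears most directly on this change, since it too replaces amino with methoxy, though compound 4 carries 3-methoxyphenyl instead. For the measured compounds named here, no measured step tests where the methoxy group sits on that ring, so only a small shift is expected. Compound 4 is therefore estimated at 4.5 ug/mL, within 2.5 ug/mL to 8.5 ug/mL. This expected step a 1.2-fold higher number from compound 1 to compound 4 (0.07 log units; within the scatter) would stay within the scatter.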

Compound 4, half-maximal inhibitory concentration: 6.1 ug/mL
Compound 4: middle estimate off by 1.4-fold (0.13 log units), on the low side, within the range that was stated.
By their numbers in this assay, from the lowest: compounds 1, 2, 4 and 3 (each within the scatter of the next, the first and the last beyond it).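

Compound 4 shifts the methoxy group to another place on the phenyl ring held by the carbonyl carbon, and a 1.4-fold higher number from compound 2 to compound 4 (0.13 log units; within the scatter) shows that in this assay 3-methoxyphenyl and 4-methoxyphenyl cannot be told apart. The wider change from 4-aminophenyl, a 1.6-fold higher number from compound 1 to compound 4 (0.21 log units; within the scatter), also cannot be separated from ordinary scatter. Nothing available explains these numbers. Still open, on these data alone, is whether 3-aminophenyl would read like 4-aminophenyl, since the amino group appears in only one place. A carboxylic acid on this phenyl ring also remains untested among the compounds shown.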